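Compound 4: a smaller ring on the carbonyl carbon

The source may hold more compounds than are shown below. What is called first, only, known or untested is meant among the compounds shown, and "the series" means these compounds.

Measured in an in vitro ADME assay on microsomes from liver (Rattus norvegicus) for metabolic stability, tested at 1 uM; on this read-out higher numbers stand for a longer-lived compound and lower numbers for a shorter-lived compound:
- Compound 1 `O=C(O)c1cccc(S(=O)(=O)N2CCC(NS(=O)(=O)c3cc(S(=O)(=O)c4ccccc4)ccc3C(F)(F)F)CC2)c1`: 0.383 h
- Compound 2 `CC(C)(O)CCN1CCC(NS(=O)(=O)c2cc(S(=O)(=O)c3ccccc3)ccc2C(F)(F)F)CC1`: 0.05 h
- Compound 3 `O=C(C1CCNCC1)N1CCC(NS(=O)(=O)c2cc(S(=O)(=O)c3ccccc3)ccc2C(F)(F)F)CC1`: > 0.5 h

Compound 3 has no exact reading in this assay, since its > 0.5 h is a limit of the assay and not a number. Compound 4 `O=C([C@H]1CCNC1)N1CCC(NS(=O)(=O)c2cc(S(=O)(=O)c3ccccc3)ccc2C(F)(F)F)CC1` keeps everything in compound 3 except one ring: pyrrolidin-3-yl in place of piperidin-4-yl on a carbonyl carbon. In words, pyrrolidin-3-yl stands in place of piperidin-4-yl on a carbonyl carbon.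

Among the compounds with values here, no measured step makes this exact swap. The closest evidence comes from the two steps that arrive at compound 3, each replacing a whole group on an amine nitrogen in a ring. One is an at least 10-fold higher number from compound 2 to compound 3 (1.00 log units; beyond the scatter), and the other is an at least 1.3-fold higher number from compound 1 to compound 3 (0.11 log units; that floor lies within the scatter). The first is large, but it exchanges far more than the change made here, where the carbonyl and a ring carrying a nitrogen both remain. The second shows only a floor within the scatter. On this thin evidence, no step beyond the scatter is expected, and no direction is favoured. The expected step is a number no higher from compound 3 to compound 4 (the limit leaves the size open). For compound 4 the estimated half-life is 0.5 h, with an expected range of 0.2 h to 1 h. A reading reported only as a limit would be no surprise.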

Compound 4, half-life: > 0.5 h
Compound 4 ended at the assay's limit; the forecaster's own chance of this, stated with the estimate: 55%; the middle value sits exactly at the limit.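

In this assay the swap of piperidin-4-yl for pyrrolidin-3-yl on a carbonyl carbon gives a step that cannot be read, because the readings of compound 3 and compound 4 are both limits of the assay and not numbers: the limit of > 0.5 h in this assay, at which 2 of the 4 values shown sit.

Even so, the result shows that this position accepts the smaller ring, with its defined stereocentre, without the half-life falling to a measurable number, and the gain seen with (piperidin-4-yl)carbonyl survives the change, as the comparison with the 3-hydroxy-3-methylbutyl compound gives an at least 10-fold higher number from compound 2 to compound 4 (1.00 log units; beyond the scatter). The comparison with the (3-carboxyphenyl)sulfonyl compound gives an at least 1.3-fold higher number from compound 1 to compound 4 (0.11 log units; that floor lies within the scatter), so it sets no order between those two.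

As far as these compounds go, whether the two ring sizes truly differ in half-life remains open, as the limit hides any gap between compound 3 and compound 4. Also open, from the compounds shown here alone, is whether the opposite stereocentre of pyrrolidin-3-yl, the still smaller azetidin-3-yl ring or an open-chain amine on the carbonyl carbon would reach the same limit in this assay.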